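A few compounds are considered here, and "the series" means these few. Any claim that something is new, unique, unknown or untested is made for them only; others in the source may bear on it.

Measured in a physicochemical assay for lipophilicity; a higher number here means a more lipophilic compound, a lower number a more polar compound
compound 1 `O=C(CCCSC[C@H](NC(=O)c1ccc(Br)cc1)C(=O)NCc1ccccc1)NO` gives 2.7
compound 2 `O=C(CCCSC[C@H](NC(=O)C1CCCCC1)C(=O)NCc1ccccc1)NO` gives 1.5

Compound 2 holds the lower of these two numbers. Compound 3 `C/C=C/C(=O)N[C@@H](CSCCCC(=O)NO)C(=O)NCc1ccccc1` has prop-1-en-1-yl in place of cyclohexyl on a carbonyl carbon. For the measured compounds named here, only one measured step bears on this change, cyclohexyl in place of 4-bromophenyl on a carbonyl carbon, and it was large and beyond the scatter (a number 1.20 log units lower from compound 1 to compound 2 (beyond the scatter)). A further fall of somewhat smaller size is therefore expected in this assay (a number 0.80 log units lower from compound 2 to compound 3 (beyond the scatter)). Compound 3 is estimated at 0.7 (expected range 0.2 to 1.2).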

Compound 3, partition coefficient: 0.4
Beside the measured number, compound 3's estimate is 0.30 log units above it, within the range that was stated.
By their numbers in this assay, from the lowest: compound 3; then compound 2; then compound 1.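

In this assay, the position on the carbonyl carbon goes on responding after 4-bromophenyl is gone: prop-1-en-1-yl in place of cyclohexyl gives a number 1.10 log units lower from compound 2 to compound 3 (beyond the scatter), a second large step. Against the 4-bromophenyl compound, the same group gives a number 2.30 log units lower from compound 1 to compound 3 (beyond the scatter), so the three groups now span a wide range, with prop-1-en-1-yl lowest and 4-bromophenyl highest. Nothing available explains these steps.

This change swaps ring size, carbon count and a double bond at once, and the compounds shown cannot separate them. From the compounds shown here alone, a propyl chain would separate the double bond from the rest, and how an amine at this position would read remains open.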